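This account rests on a few compounds, and the source may have more. Where it says the series, first, only, none or still open, it means among the compounds named here.

In an assay on isolated protein for binding affinity to fibroblast growth factor 2 (Homo sapiens), read by surface plasmon resonance (on this read-out lower numbers stand for tighter binding and higher numbers for weaker binding), the measured compounds are: compound 1 `CO[C@H]1O[C@H](CNC(=O)CN(CCOS(=O)(=O)O)C(C)=O)[C@@H](OS(=O)(=O)O)[C@H](OS(=O)(=O)O)[C@@H]1OS(=O)(=O)O` with 240000 nM; compound 2 `CCN(CC(=O)NC[C@H]1O[C@H](OC)[C@@H](OS(=O)(=O)O)[C@@H](OS(=O)(=O)O)[C@@H]1OS(=O)(=O)O)C(=O)CCCCCCCCCOS(=O)(=O)O` with 240000 nM; compound 3 `CO[C@H]1O[C@H](CNC(=O)CN(C(C)=O)C2CCCCC2)[C@@H](OS(=O)(=O)O)[C@H](OS(=O)(=O)O)[C@@H]1OS(=O)(=O)O` with 413000 nM.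

Compound 3 cannot be told apart from either of the other two in this assay, since its number and theirs lie within the usual scatter of each other. Compound 4 `CCN(CC(=O)NC[C@H]1O[C@H](OC)[C@@H](OS(=O)(=O)O)[C@@H](OS(=O)(=O)O)[C@@H]1OS(=O)(=O)O)C(=O)CCCCC(=O)O` differs from compound 3 by ((4-carboxybutyl)carbonyl)(ethyl)amino in place of acetyl(cyclohexyl)amino on a saturated chain carbon bound to a carbonyl carbon. Within the data shown here, the one measured step that bears on this position, a 1.7-fold higher number from compound 1 to compound 3 (0.24 log units; within the scatter), stayed within the scatter, and compound 2, which likewise carries an ethyl group, gave 240000 nM, a number within the scatter of compound 3. Accordingly compound 4 is expected to show no step beyond the scatter, a 1.5-fold lower number from compound 3 to compound 4 (0.18 log units; within the scatter). The estimate for compound 4 in this assay is 270000 nM, ranging from 130000 nM to 560000 nM.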

Compound 4, dissociation constant: 480000 nM
The estimate for compound 4 lay 1.8-fold (0.25 log units) below the measured number, and the stated range covers the measured number.
By their numbers in this assay, from the lowest: compounds 1, 2, 3 and 4 (each within the scatter of the next).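

In this assay, ((4-carboxybutyl)carbonyl)(ethyl)amino in place of acetyl(cyclohexyl)amino stayed within the scatter (a 1.2-fold higher number from compound 3 to compound 4 (0.07 log units; within the scatter)), so a carboxy group on this chain did not separate compound 4 from the cyclohexyl compound. Carboxy in place of 5-(sulfooxy)pentyl (a 2.0-fold higher number from compound 2 to compound 4 (0.30 log units; within the scatter)) and ((4-carboxybutyl)carbonyl)(ethyl)amino in place of acetyl(2-(sulfooxy)ethyl)amino (a 2.0-fold higher number from compound 1 to compound 4 (0.30 log units; within the scatter)) also stayed within it, so compound 4 cannot be told apart from any of the other three. Nothing measured here explains this. On these data alone, whether an amine or a longer chain ending in a phosphate at this position would give a step beyond the scatter remains open.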